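Shifting a Methyl Group and the Tolerated Concentration

The source may report more compounds than this note shows. Statements on the series, on what has been measured and on what is new or still open speak of the compounds shown alone.

Compound 1, `CCCCOC(=O)/C=C/c1ccc(OS(=O)(=O)c2ccc(Cl)cc2)c(OC)c1`, gives 14000 nM in a toxicity assay on L02 cells (Homo sapiens) for cytotoxicity, read by MTT assay, with a stated time of 24 h; a lower number here means that less compound is tolerated, a higher number that more compound is tolerated.
Compound 2, `CCCCS(=O)(=O)Oc1ccc(/C=C/C(=O)Nc2ccccc2C)cc1OC`, gives 56100 nM in this assay.

Of the two measured compounds, compound 2 stands at the higher number: more of it is tolerated by the cells than of compound 1, and the gap between the two lies beyond the usual scatter. Compound 3, `CCCCS(=O)(=O)Oc1ccc(/C=C/C(=O)Nc2cccc(C)c2)cc1OC`, has not yet been measured in this assay. It differs from compound 2 in one place only: 3-methylphenyl in place of 2-methylphenyl on an amide-type nitrogen. Within the data shown here, no step between two measured compounds that differ in a single place is available here, so there is nothing measured to lean on for this change. Moving the methyl from one place on the ring to another keeps all atoms the same, and the expected step from compound 2 to compound 3 is a 1.1-fold lower number from compound 2 to compound 3 (0.05 log units; within the scatter), which is not expected to exceed the scatter. Compound 3 is therefore estimated to give 50000 nM in this assay, with a range from 20000 nM to 125000 nM.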

Compound 3, half-maximal cytotoxic concentration: 33600 nM
Compound 3: middle estimate off by 1.5-fold (0.17 log units), on the high side; low and high end bracket the measured number.
By their numbers in this assay, from the lowest: compound 1; then compounds 3 and 2 (each within the scatter of the next).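

Shifting the methyl group, so that 3-methylphenyl replaces 2-methylphenyl on the amide-type nitrogen, gives the first measured single-place step here, and in this assay it reads a 1.7-fold lower number from compound 2 to compound 3 (0.22 log units; within the scatter) for this change. For this pair, then, the methyl group's place on the ring does not clearly separate how much compound the cells tolerate, as the two numbers cannot be told apart from repeat measurement. Nothing measured here accounts for the small difference between the two compounds.

Still open, on these data alone, is whether 4-methylphenyl, or a phenyl ring carrying an amine or a carboxylic acid, would also stay within the scatter of compound 2. Also open, as far as these compounds go, is whether the same methyl shift would read alike with a longer chain elsewhere on the shared core.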